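The source may hold more compounds than are shown below. What is called first, only, known or untested is meant among the compounds shown, and "the series" means these compounds.

Values in a functional assay for inhibition, with Homo sapiens as the target; on this read-out lower numbers stand for stronger inhibition and higher numbers for weaker inhibition:
- compound 1 `COc1ccc(O)c(CNc2ccccc2)c1`: 4700 nM
- compound 2 `Oc1cc2c(cc1CNc1ccccc1)OCCC2`: 1700 nM
- compound 3 `CC(=O)c1ccc(NCc2cc3c(cc2O)CCCO3)cc1`: 4100 nM

Compound 3 has the second highest of the three numbers in this assay. At 4100 nM, compound 3 lies within the scatter of compound 1 at 4700 nM. The clear gap is to compound 2, at a 2.4-fold higher number from compound 2 to compound 3 (0.38 log units; beyond the scatter).

The next compound is compound 4 `CCOC(=O)c1ccc(NCc2cc3c(cc2O)CCCO3)cc1`. The change is ethoxy in place of methyl on a carbonyl carbon, which reads as acetyl to ethoxycarbonyl: ethoxy in place of methyl on a carbonyl carbon.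

Within the data shown here, no measured step exchanges one carbonyl group for another, so the series gives no direct precedent. Among the measured compounds shown here, the only step that bears on this one is a 2.4-fold higher number from compound 2 to compound 3 (0.38 log units; beyond the scatter), where acetyl replaces hydrogen on an aromatic carbon. That step is modest and rests on a single pair. Swapping the group attached to the carbonyl carbon, with the carbonyl itself retained, is therefore not expected to move the number by more than that step did.

The estimated step is a 1.1-fold lower number from compound 3 to compound 4 (0.03 log units; within the scatter), so no change beyond the scatter is expected, though the direction is poorly defined. For compound 4 the expected value is 3800 nM, with an estimated range of 1700 nM to 8500 nM.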

Compound 4, half-maximal inhibitory concentration in the Homo sapiens assay: 600 nM
Compound 4: middle estimate off by 6.3-fold (0.80 log units), on the high side; measured number below the stated range.
By their numbers in the Homo sapiens assay, from the lowest: compound 4; then compound 2; then compounds 3 and 1 (each within the scatter of the next).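

In the Homo sapiens assay, the aromatic carbon carrying the new group does not respond in one direction to substitution: acetyl gives a 2.4-fold higher number from compound 2 to compound 3 (0.38 log units; beyond the scatter), whereas ethoxycarbonyl gives a 2.8-fold lower number from compound 2 to compound 4 (0.45 log units; beyond the scatter). With the carbonyl retained, the group on the carbonyl carbon therefore decides the outcome, and ethoxy in place of methyl gives a 6.8-fold lower number from compound 3 to compound 4 (0.83 log units; beyond the scatter). In a physicochemical assay for lipophilicity (on this read-out higher numbers stand for higher lipophilicity and lower numbers for lower lipophilicity), compound 3 gives 3.5 and compound 4 gives 4.6; the same change thus also raises lipophilicity, so the stronger inhibition of compound 4 coincides with a higher lipophilicity, although this single pair cannot show that one drives the other: the measured partition coefficient of compound 3, 3.5, and of compound 4, 4.6, a number 1.10 log units higher (beyond the scatter)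

Going by these compounds, it remains open whether the gain follows the added oxygen of the ethoxy group, the larger group on the carbonyl carbon, or the lipophilicity itself; an amine or a hydroxyl in place of ethoxy, giving an amide or a carboxylic acid, or a longer chain on the same oxygen, would help to separate these readings. The compounds shown also leave open whether ethoxycarbonyl has the same effect on the core of compound 1.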